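Thiosemicarbazone Growth Inhibition: From Ethyl to Chloro

This account rests on a few compounds, and the source may have more. Where it says the series, first, only, none or still open, it means among the compounds named here.

Compound 1 `S=C(N/N=C/c1cccs1)Nc1ccccc1` gives only a limit, > 100000 nM, in a functional assay on UACC-62 cells (Homo sapiens) for inhibition, read by sulforhodamine B assay, with a stated time of 48 h; a lower number here means a stronger inhibitor of growth, a higher number a weaker inhibitor of growth.
Compound 2 `CCc1ccc(NC(=S)N/N=C/c2cccs2)cc1` gives only a limit, > 100000 nM, in this assay.
Compound 3 `S=C(N/N=C/c1cccs1)Nc1cccnc1` gives only a limit, > 100000 nM, in this assay.

Compound 2 thus stands at the limit of this assay, where all three measured compounds sit (the limit of > 100000 nM in this assay, at which 3 of the 3 values shown sit). The step from compound 1 to compound 2 is a step that the two limits leave unreadable from compound 1 to compound 2. Compound 4 `S=C(N/N=C/c1cccs1)Nc1ccc(Cl)cc1` differs from compound 2 by chloro in place of ethyl on an aromatic carbon. No measured step reads as a number, so the size of this change cannot be gauged from the shown values. Because every measured compound sits at the limit (the limit of > 100000 nM in this assay, at which 3 of the 3 values shown sit), compound 4 is expected to remain there, with a step of a number no higher from compound 2 to compound 4 (the limit leaves the size open) not beyond the scatter. Compound 4 is estimated at 100000 nM, within 30000 nM to 300000 nM.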

Compound 4, concentration for 50% growth inhibition: 15800 nM
Compound 4: middle estimate off by 6.3-fold (0.80 log units), on the high side; the whole stated range lies above it.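

Chloro in place of ethyl gives an at least 6.3-fold lower number from compound 2 to compound 4 (0.80 log units; beyond the scatter) in this assay, and chloro in place of hydrogen gives an at least 6.3-fold lower number from compound 1 to compound 4 (0.80 log units; beyond the scatter) at the same aromatic carbon, para to a large group. This position is therefore one where a single group takes the shared core off the limit, which neither hydrogen nor ethyl there did. Both steps are bounded on one side only: compound 1 and compound 2 each give a limit, not a number.

Going by these compounds, whether bromo, fluoro, an amine or a carboxylic acid at this position would read lower or higher than chloro stays open.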